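Working notes on four analogues, one still to be measured

A few compounds are considered here, and "the series" means these few. Any claim that something is new, unique, unknown or untested is made for them only; others in the source may bear on it.

Measured compounds:
Compound 1 `Cc1nnc(SCC(=O)c2ccccc2)n1N1C(=O)c2ccccc2C1=O` gives in a functional assay on PC-3M cells (Homo sapiens) for cytotoxicity, read by MTT assay, with a stated time of 48 h (on this read-out higher numbers stand for weaker inhibition and lower numbers for stronger inhibition), only a limit, > 200000 nM.
Compound 2 `C=CCSc1nnc(CC)n1N1C(=O)c2ccccc2C1=O` gives in this assay only a limit, > 200000 nM.
Compound 3 `CCc1nnc(SCC(=O)c2ccccc2)n1N1C(=O)c2ccccc2C1=O` gives in this assay only a limit, > 200000 nM.

All three values are limits of the assay rather than numbers, so no ordering among them can be read. The change from compound 1 to compound 3, (methyl in place of hydrogen on a saturated chain carbon bound to an aromatic carbon), gives a step that the two limits leave unreadable from compound 1 to compound 3. The change from compound 2 to compound 3, a step that the two limits leave unreadable from compound 2 to compound 3, is likewise unreadable. Compound 2 and compound 1 differ in more than one place, and the difference between the two cores is not broken down here. For the measured compounds named here, the only evidence on these steps is the limit of > 200000 nM in this assay, at which 3 of the 3 values shown sit.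

Compound 4 `C=CCSc1nnc(CCC)n1N1C(=O)c2ccccc2C1=O` remains to be measured. It differs from compound 2 by methyl in place of hydrogen on a saturated chain carbon, two bonds along the chain from an aromatic carbon. This is the same kind of change as that from compound 1 to compound 3, but the place differs: there the methyl enters on a saturated chain carbon bound to an aromatic carbon, here on a saturated chain carbon, two bonds along the chain from an aromatic carbon. For compound 4 the expected step in this assay is estimated as a step that the limit leaves unreadable from compound 2 to compound 4. That expectation rests on compound 2 sitting at the limit of > 200000 nM in this assay, at which 3 of the 3 values shown sit, together with the other two. For compound 4 the expected value is 250000 nM, estimated to lie between 100000 nM and 600000 nM.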

Compound 4, half-maximal inhibitory concentration: > 200000 nM
Compound 4 was reported as a limit; the forecaster's own chance of this, stated with the estimate: 85%; the middle value is on the limit's open side.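

Compound 4, like compound 2, is reported only as a limit in this assay and so no new step can be read between the two compounds. For the compounds shown here, the sole evidence is this: the limit of > 200000 nM in this assay, at which 4 of the 4 values shown sit. The compounds shown leave open whether any member of this series gives a numerical value in this assay and what size the change from hydrogen to methyl has on either chain.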